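The source may hold more compounds than are shown below. What is called first, only, known or untested is meant among the compounds shown, and "the series" means these compounds.

Working notes on the series. Compound 1 `C=C[C@@](C)(/C=C/c1ccc(Nc2ccccc2)cc1)CCC=C(C)C` carries an anilino group on the shared core. In a functional assay on NALM-6 cells (Homo sapiens) for cytotoxicity, with a stated time of 72 h (on this read-out lower numbers stand for an effect already at smaller amounts and higher numbers for an effect only at larger amounts of compound), compound 1 returns only the limit of > 43400 nM, so its standing is a limit rather than a number. Compound 2 `C=C[C@@](C)(/C=C/c1ccc(Nc2cc(F)c(F)cc2F)cc1)CCC=C(C)C` likewise returns only the limit of > 43400 nM in this assay. Compound 3 `C=C[C@@](C)(/C=C/c1ccc(Nc2c(F)cc(F)cc2F)cc1)CCC=C(C)C` also sits at the limit of > 43400 nM in this assay. Hence a step that the two limits leave unreadable from compound 1 to compound 2, a step that the two limits leave unreadable from compound 1 to compound 3 and a step that the two limits leave unreadable from compound 2 to compound 3 all remain unreadable, since (the limit of > 43400 nM in this assay, at which 3 of the 3 values shown sit). Compound 4 `C=C[C@@](C)(/C=C/c1ccc(-c2ccc(Cl)cc2)cc1)CCC=C(C)C` is the next entry; it differs from compound 1 by 4-chlorophenyl in place of anilino on an aromatic carbon. Among the measured compounds shown here, no measured step bears directly on this change: the two fluorinated variants only exchange the ring on the nitrogen, and none of the three left the limit. Compound 1 stays at the limit of > 43400 nM. The step of a number no higher from compound 1 to compound 4 (the limit leaves the size open) is therefore expected to remain unreadable against the same limit. Compound 4 is expected to give 43400 nM, within a range of 10000 nM to 120000 nM, most likely as another limit.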

Compound 4, half-maximal effective concentration: > 43400 nM
Compound 4: only a limit was reported; the forecaster's own chance of this, stated with the estimate: 75%; the middle value lies on the limit itself.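

Compound 4 adds no readable step against compound 1, because both compounds sit at the same limit, which is not a number: the limit of > 43400 nM in this assay, at which 4 of the 4 values shown sit.

The compounds shown leave open what effect, if any, the exchange of anilino for 4-chlorophenyl or the fluorinated variants have in this assay.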